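The source may hold more compounds than are shown below. What is called first, only, known or untested is meant among the compounds shown, and "the series" means these compounds.

The measured compounds in an assay on isolated protein for inhibition of tyrosine-protein kinase receptor UFO (Homo sapiens), read by FRET and Z'-LYTE, with a stated time of 1.5 h; on this read-out lower numbers stand for stronger inhibition and higher numbers for weaker inhibition:

Compound 1 `Cc1c(C(=O)Nc2ccc(Oc3ncnc4[nH]cc(-c5ccccc5)c34)c(F)c2)c(=O)c2cc(C3CC3)ccc2n1C` gives 230 nM.
Compound 2 `Cc1c(C(=O)Nc2ccc(Oc3ncnc4[nH]cc(-c5ccccc5)c34)c(F)c2)c(=O)c2cc(C(C)C)ccc2n1C` gives 26 nM.
Compound 3 `Cc1c(C(=O)Nc2ccc(Oc3ncnc4[nH]cc(-c5ccccc5)c34)c(F)c2)c(=O)c2cc(C3=CCCC3)ccc2n1C` gives 3320 nM.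

Compound 3 stands highest of the three; the nearest is compound 1, as a 14-fold higher number from compound 1 to compound 3 (1.16 log units; beyond the scatter) shows, and the furthest is compound 2, as a 130-fold higher number from compound 2 to compound 3 (2.11 log units; beyond the scatter) shows. The unmeasured compound 4 `Cc1c(C(=O)Nc2ccc(Oc3ncnc4[nH]cc(-c5ccccc5)c34)c(F)c2)c(=O)c2cc(-c3ccccc3)ccc2n1C` differs from compound 3 by phenyl in place of cyclopent-1-en-1-yl on an aromatic carbon. Among the measured compounds shown here, no measured step exchanges one ring for another on this carbon. The steps that introduce the cyclopent-1-en-1-yl ring, a 14-fold higher number from compound 1 to compound 3 (1.16 log units; beyond the scatter) and a 130-fold higher number from compound 2 to compound 3 (2.11 log units; beyond the scatter), were large and both raised the number, while an 8.8-fold lower number from compound 1 to compound 2 (0.95 log units; beyond the scatter) shows a modest move between the two small groups. For the measured compounds named here, with no direct precedent, the step of a 1.3-fold lower number from compound 3 to compound 4 (0.12 log units; within the scatter) is expected to remain within the scatter. Compound 4 is therefore estimated at 2500 nM, with a range from 500 nM to 12000 nM.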

Compound 4, half-maximal inhibitory concentration: > 10000 nM
Compound 4 ended at the assay's limit; the forecaster's own chance of this, stated with the estimate: 10%; middle value at least 4.0-fold (0.60 log units) away from the limit.
By their numbers in this assay, from the lowest: compound 2; then compound 1; then compound 3. At a limit, above all of these: compound 4.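

Compound 4 is held at a limit, not a number, in this assay: the limit of > 10000 nM in this assay, at which 1 of the 4 values shown sits. Among the compounds shown here, this is the first ring-for-ring exchange on this aromatic carbon, and an at least 3.0-fold higher number from compound 3 to compound 4 (0.47 log units; beyond the scatter) shows that phenyl does not restore what the cyclopent-1-en-1-yl ring lost. The steps of an at least 43-fold higher number from compound 1 to compound 4 (1.63 log units; beyond the scatter) and an at least 380-fold higher number from compound 2 to compound 4 (2.58 log units; beyond the scatter) place phenyl further from both cyclopropyl and isopropyl than the cyclopent-1-en-1-yl ring stands.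

As far as these compounds go, how far the number of compound 4 lies past its limit stays open. So does whether a saturated cyclopentyl ring, a morpholine or a methyl group on this carbon would follow isopropyl or phenyl.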